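This account rests on a few compounds, and the source may have more. Where it says the series, first, only, none or still open, it means among the compounds named here.

Values measured so far in an ADME assay on microsomes from liver (Mus musculus) for metabolic stability, with a stated time of 30 min, tested at 1 uM (on this read-out higher numbers stand for a more stable compound and lower numbers for a less stable compound), are few:

- compound 1 (`CC[C@@H]1C(=O)N(C)c2cnc(-c3cn[nH]c3-c3ccc(F)cc3F)nc2N1c1cnn(C)c1`) stands at 5%
- compound 2 (`CC[C@@H]1C(=O)N(C)c2cnc(-n3ccnc3-c3ccccc3)nc2N1[C@@H]1CCOC1`) stands at 27%
- compound 3 (`CC[C@@H]1C(=O)N(C)c2cnc(-n3ccnc3-c3ccc(F)cc3)nc2N1[C@H]1CCOC1`) stands at 63%

Compound 2 at 27% is the second highest of the three, beyond the scatter above compound 1 and beyond the scatter below compound 3. The next compound to be read is compound 4 (`CC[C@@H]1C(=O)N(C)c2cnc(-n3ccnc3-c3ccccc3)nc2N1C1CCCC1`), which has no number yet in this assay and departs from compound 2 at a single place. It carries cyclopentyl in place of oxolan-3-yl on a nitrogen on an aromatic ring in a ring, and the rest of the structure is unchanged.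

For the measured compounds named here, no measured pair shows this exchange on its own, so the direction is a judgement and not a reading. Compound 2 at 27% leaves room for a fall, and a moderate downward step, just beyond the scatter, is expected. The estimate amounts to a number 13 percentage points lower from compound 2 to compound 4 (beyond the scatter) as the expected change, though a step within the scatter would not surprise. For compound 4 the estimated value is 14% in this assay, with 4% to 30% as the expected range.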

Compound 4, percent of the compound remaining: 0%
For compound 4 the middle estimate is 14 percentage points above the measured one; measured number outside the range, below it.
By their numbers in this assay, from the lowest: compounds 4 and 1 (each within the scatter of the next); then compound 2; then compound 3.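

In this assay, the exchange at this nitrogen on an aromatic ring gives a number 27 percentage points lower from compound 2 to compound 4 (beyond the scatter), and compound 4 stands at 0%. Compounds 1 and 3 each differ from compound 2 in more than one place, so this is the only step shown that isolates the group at this position: a ring of the same size and the same heavy-atom count, in which oxolan-3-yl carries one oxygen and one hydrogen-bond acceptor and cyclopentyl is carbon only, with the defined stereocentre of oxolan-3-yl also gone. Nothing measured here explains the size of this step.

The compounds shown leave open whether the ring oxygen itself matters or whether another group on this nitrogen, such as oxan-4-yl, a pyrrolidine amine or an open isopropyl chain, would read differently. They also leave open how much the configuration of oxolan-3-yl contributes, since compound 3 differs from compound 2 in that configuration and also carries a fluorine, so the two changes cannot be separated.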